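Fluoro added to the hydroxyphenyl of compound 2

The source may report more compounds than this note shows. Statements on the series, on what has been measured and on what is new or still open speak of the compounds shown alone.

Measured compounds:
compound 1, `CN(C)CCn1cnnc1-c1cc(Oc2ccc(NC(=O)N/N=C/c3cccc(Br)c3)cc2F)ccn1`, gives 520 nM in a functional assay on NCI-H460 cells (Homo sapiens) for cytotoxicity, read by MTT assay, with a stated time of 72 h; a higher number here means a weaker inhibitor, a lower number a stronger inhibitor.
compound 2, `CN(C)CCn1cnnc1-c1cc(Oc2ccc(NC(=O)N/N=C/c3ccc(O)cc3)cc2F)ccn1`, gives 1780 nM in this assay.

Going by the values given here, compound 2 stands at the highest of the two numbers; its nearest neighbour is compound 1, and the only step available, a 3.4-fold higher number from compound 1 to compound 2 (0.53 log units; beyond the scatter), shows that swapping the aryl group on the carbon with a double bond to nitrogen moves the read-out by a modest amount. Compound 3, `CN(C)CCn1cnnc1-c1cc(Oc2ccc(NC(=O)N/N=C/c3ccc(O)c(F)c3)cc2F)ccn1`, differs from compound 2 by fluoro in place of hydrogen on an aromatic carbon; the same difference, cut one bond further out, reads 4-hydroxyphenyl to 3-fluoro-4-hydroxyphenyl. Among the compounds with values here, no measured pair covers a change of this kind: the one step known exchanges the whole ring rather than adding a single atom to it, so it bears on compound 3 only by showing that this part of the molecule is not inert. Because the change is a single fluorine on a ring that already gave 1780 nM for compound 2, no step beyond the scatter is expected. Compound 3 is therefore estimated at 1300 nM in this assay, with a range of 450 nM to 3800 nM, which means an expected step of a 1.4-fold lower number from compound 2 to compound 3 (0.14 log units; within the scatter).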

Compound 3, half-maximal inhibitory concentration: 2620 nM
Compound 3: the middle estimate sits 2.0-fold (0.30 log units) below what was measured; low and high end bracket the measured number.
By their numbers in this assay, from the lowest: compound 1; then compounds 2 and 3 (each within the scatter of the next).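

In this assay, going by these compounds alone, fluoro in place of hydrogen on the aromatic carbon ortho to the hydroxy group gives a 1.5-fold higher number from compound 2 to compound 3 (0.17 log units; within the scatter) and so produces no step that can be told from the scatter, which shows that this ring position accepts the added atom without a readable change in the cytotoxicity read-out. Within the data shown here, the earlier step showed only that exchanging the whole ring matters, whereas this one shows that a single fluoro on the 4-hydroxyphenyl ring does not bring the read-out to that of compound 1, as a 5.0-fold higher number from compound 1 to compound 3 (0.70 log units; beyond the scatter) still lies beyond the scatter. Nothing given here explains why the 3-bromophenyl ring and the two hydroxy-bearing rings differ.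

The compounds shown leave open whether the hydroxy group itself accounts for the gap to compound 1, since they do not tell how a 3-bromo-4-hydroxyphenyl ring, a 4-methoxyphenyl ring or a 4-aminophenyl ring would read. They also leave open whether a larger group than fluoro, such as chloro or methyl, at this same carbon would give a step beyond the scatter.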